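Half-life of compound 1 and its phenyl analogue

The compounds below may be only part of what the source reports. "The series", "measured", "known", "first", "only" and "open" are said of these compounds alone.

Measured in an ADME assay on microsomes from liver (Rattus norvegicus, strain Sprague-Dawley) for metabolic stability, read by LC-MS, using NADPH, with a stated time of 45 min, tested at 3 uM (on this read-out higher numbers stand for a longer-lived compound and lower numbers for a shorter-lived compound), as follows:
- compound 1 `C1CCC(C(CC2CCCCN2)C2CC2)CC1` gives 0.05 h
- compound 2 `C1CCC(CC(C2CCCC2)C2CC2)NC1` gives 0.05 h

Among the measured compounds shown here, compound 1 stands level with compound 2, the only other measured compound, and the two values lie within the scatter of each other. The next compound to be read is compound 3 `c1ccc(C(CC2CCCCN2)C2CCCCC2)cc1` and it differs from compound 1 in one place: phenyl in place of cyclopropyl on a saturated chain carbon bound to a saturated chain carbon and a saturated ring carbon. For the measured compounds named here, no measured step covers this change, so this assay gives no direct guide to its size. Going by the values given here, the only anchor is compound 1 at 0.05 h and no step beyond the scatter is expected, in either direction. The expected change a 1.2-fold higher number from compound 1 to compound 3 (0.08 log units; within the scatter) is estimated to stay within the scatter. Compound 3 is expected at 0.06 h with an estimated range of 0.03 h to 0.15 h for its half-life.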

Compound 3, half-life: 0.0667 h
The estimate for compound 3 lay 1.1-fold (0.05 log units) below the measured number; the measured number falls inside the stated range.
By their numbers in this assay, from the lowest: compounds 1, 2 and 3 (each within the scatter of the next).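

In this assay, among the compounds shown here, phenyl in place of cyclopropyl on a saturated chain carbon bound to a saturated chain carbon and a saturated ring carbon gives a 1.3-fold higher number from compound 1 to compound 3 (0.13 log units; within the scatter), the first measured step at this position. The half-life read-out therefore does not separate a six-membered aromatic ring of carbon from a three-membered non-aromatic ring of carbon here, even though the entering group has more heavy atoms than the one leaving. No supporting measurement bears on why this step stays within the scatter.

From the compounds shown here alone, it remains open whether a pyridyl ring or a fluorophenyl group at this position would give a step beyond the scatter. Going by these compounds, the effect of a carboxylic acid or a hydroxyl group elsewhere on the shared core is also open.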